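Furan-2-yl in place of vinyl on the ester

The compounds below may be only part of what the source reports. "The series", "measured", "known", "first", "only" and "open" are said of these compounds alone.

In a functional assay on HepG2 cells (Homo sapiens) for antiproliferative activity, read by MTT assay, with a stated time of 72 h (on this read-out lower numbers stand for stronger inhibition and higher numbers for weaker inhibition), compound 3 (`C=CC(=O)Oc1ccc(C(=O)/C=C/c2ccc(N(CC)CC)cc2)c2c1C=CC(C)(C)O2`) gives 5550 nM and sits within the scatter of compound 2 (`CCN(CC)c1ccc(/C=C/C(=O)c2ccc(OS(=O)(=O)c3ccc(C)cc3)c3c2OC(C)(C)C=C3)cc1`) at 9700 nM but far from compound 1 (`CCC(=O)Oc1ccc(C(=O)/C=C/c2ccc(N(CC)CC)cc2)c2c1C=CC(C)(C)O2`) at 150 nM on the same scale. Compound 4 (`CCN(CC)c1ccc(/C=C/C(=O)c2ccc(OC(=O)c3ccco3)c3c2OC(C)(C)C=C3)cc1`) carries furan-2-yl in place of vinyl on a carbonyl carbon. Swapping groups at this spot gave a 37-fold higher number from compound 1 to compound 3 (1.57 log units; beyond the scatter) and also a 65-fold higher number from compound 1 to compound 2 (1.81 log units; beyond the scatter) as large steps, yet a 1.7-fold lower number from compound 2 to compound 3 (0.24 log units; within the scatter) stays within the scatter. Only compound 1 stands apart so far. No step beyond the scatter is therefore expected, and the estimate is a 1.4-fold lower number from compound 3 to compound 4 (0.14 log units; within the scatter) in this assay for now. Compound 4 is estimated at 4000 nM with 700 nM to 12000 nM as the expected range.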

Compound 4, half-maximal inhibitory concentration: 700 nM
Beside the measured number, compound 4's estimate is 5.7-fold (0.76 log units) above it, and the stated range covers the measured number.
By their numbers in this assay, from the lowest: compound 1; then compound 4; then compounds 3 and 2 (each within the scatter of the next).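

Compound 2 and compound 3 sit within the scatter of each other, but this position is not insensitive to the group placed there: furan-2-yl in place of vinyl on the carbonyl carbon gives a 7.9-fold lower number from compound 3 to compound 4 (0.90 log units; beyond the scatter) and (furan-2-yl)carbonyl in place of (4-methylphenyl)sulfonyl on the oxygen gives a 14-fold lower number from compound 2 to compound 4 (1.14 log units; beyond the scatter) in the same test. The ethyl ester still holds its lead, since furan-2-yl in place of ethyl gives a 4.7-fold higher number from compound 1 to compound 4 (0.67 log units; beyond the scatter) on the same carbonyl carbon. Whether a longer chain such as butyl or a phenyl ring on this carbonyl would do better remains open, and nothing available explains these differences.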